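The source may hold more compounds than are shown below. What is called first, only, known or untested is meant among the compounds shown, and "the series" means these compounds.

Working notes on the series.

Among the measured compounds shown here, compound 1 `Cc1nc2c(OCc3ccccc3)cccn2c1N` is the reference; in a functional assay on the whole organism with Rattus norvegicus as the target, at a dose of 40 mg/kg by the intraperitoneal route (on this read-out lower numbers stand for less inhibition and higher numbers for more inhibition at the one dose given (going by the name of the read-out)), compound 1 gives 99%, the highest of the three numbers so far. Compound 2 `CC(C)(C)c1nc2c(OCc3ccccc3)cccn2c1N` gives 0% in this assay, and compound 3 `Cc1nc2c(OCc3ccc(C(F)(F)F)cc3)cccn2c1N` gives 78% in this assay. The two measured steps are a number 99 percentage points lower from compound 1 to compound 2 (beyond the scatter), tert-butyl in place of methyl on an aromatic carbon, and a number 21 percentage points lower from compound 1 to compound 3 (beyond the scatter), trifluoromethyl in place of hydrogen on an aromatic carbon.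

Compound 4 `CC(=O)Nc1c(C)nc2c(OCc3ccccc3)cccn12` differs from compound 1 by acetyl in place of hydrogen on a nitrogen on an aromatic ring, that is amino to acetamido. For the measured compounds named here, neither measured step touches this nitrogen, so no step bears on it directly; what they show is only that one change elsewhere cost everything and another cost a modest amount, so any departure from compound 1 has so far been a loss. A drop in this assay is therefore expected, of uncertain size, and the expected step is a number 49 percentage points lower from compound 1 to compound 4 (beyond the scatter). The estimate for compound 4 is 50% in this assay, with a range from 10% to 90%.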

Compound 4, a percentage reported as inhibition, in the whole organism at one dose (the size of the read-out at that dose, not a potency): 93%
Estimate against measurement, compound 4: 43 percentage points below; measured number above the stated range.
By their numbers in this assay, from the lowest: compound 2; then compound 3; then compounds 4 and 1 (each within the scatter of the next).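

In this assay, acetyl in place of hydrogen on a nitrogen on an aromatic ring gives a number 6 percentage points lower from compound 1 to compound 4 (within the scatter), so amino to acetamido is the only one of the three measured changes that stays within the scatter. The free amino group of compound 1 is therefore not required for this read-out at this dose, and this nitrogen accepts the acetyl group without a measurable loss. Nothing available on the series accounts for this result.

Going by these compounds, whether the same nitrogen also accepts a benzoyl group, a methanesulfonyl group or a simple methyl group remains open, as does whether the acetyl group is accepted alongside the tert-butyl or trifluoromethyl changes. A single dose also leaves open whether compound 1 and compound 4 differ in potency.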